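Compound 1 to compound 3: an aryl exchange and clearance

A few compounds are considered here, and "the series" means these few. Any claim that something is new, unique, unknown or untested is made for them only; others in the source may bear on it.

Of the compounds shown here, two carry a number so far. In an ADME assay on microsomes from liver (Homo sapiens) for metabolic stability (on this read-out higher numbers stand for fast clearance and lower numbers for slow clearance), compound 1 (`Cc1ccc(-c2c(-c3nn(C)c4ncnc(N5CCC5)c34)cnn2C)cc1`) gives 47 mL/min/kg and stands lowest, while compound 2 (`CC(C)Cc1nn(C)c2ncnc(N3Cc4ccccc4C3)c12`) gives 123 mL/min/kg at a distance beyond the scatter. These two differ in more than one place, so their gap says nothing about any single group.

The next structure is compound 3 (`Cn1ncc(-c2nn(C)c3ncnc(N4CCC4)c23)c1-c1ncc(C2CC2)cn1`), which keeps the core of compound 1 and carries 5-cyclopropylpyrimidin-2-yl in place of 4-methylphenyl on an aromatic carbon. Within the data shown here, no measured step covers this exchange, so the data do not show directly how this assay responds to it. The expectation therefore starts from compound 1 at 47 mL/min/kg and stays modest: a small move toward slower clearance that does not go beyond the scatter. The estimated step is a 1.3-fold lower number from compound 1 to compound 3 (0.12 log units; within the scatter) and remains uncertain. In this assay compound 3 is estimated at 36 mL/min/kg with an expected range from 16 mL/min/kg to 80 mL/min/kg around that middle.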

Compound 3, clearance: 28 mL/min/kg
The estimate for compound 3 lay 1.3-fold (0.11 log units) above the measured number; low and high end bracket the measured number.
By their numbers in this assay, from the lowest: compounds 3 and 1 (each within the scatter of the next); then compound 2.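

Working notes on the aryl position: in this assay, placing 5-cyclopropylpyrimidin-2-yl in place of 4-methylphenyl on an aromatic carbon gives a 1.7-fold lower number from compound 1 to compound 3 (0.22 log units; within the scatter), so this read-out does not separate the two compounds. Among these compounds, this gives the first reading at this position, on the five-membered aromatic ring with 2 nitrogen: a group with one six-membered aromatic ring with 2 hetero atoms, a three-membered non-aromatic ring and 2 hydrogen-bond acceptors leaves the clearance number within the scatter of that of the 4-methylphenyl compound. No supporting measurement bears on this result.

A single exchange at this position cannot show how the two parts of the entering group, the cyclopropyl and the pyrimidin-2-yl ring, would each read on their own, so neither can be judged separately from the other. Also open, going by these compounds, is how this assay would respond at the same aromatic carbon to quite different groups, such as a carboxylic acid, an amine or a longer alkyl chain on the aromatic ring.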